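The source may hold more compounds than are shown below. What is called first, only, known or untested is meant among the compounds shown, and "the series" means these compounds.

Measured so far:
compound 1 `Cc1ccc(Oc2ccc3nc(COc4cccc(C(=O)O)c4)n(C)c3n2)c(C)c1` with 0.9 ug/mL
compound 2 `Cc1ccc(Oc2ccc3nc(COc4cccc(C(=O)O)c4)n(C)c3n2)cc1C` with 16 ug/mL
compound 3 `Cn1c(COc2cccc(C(=O)O)c2)nc2ccc(Oc3ccc(Cl)cn3)cc21` with 17 ug/mL

The three measured compounds share a core and differ only in the aryl group carried on the oxygen on the aromatic ring. In a physicochemical assay for solubility, read by HPLC, measured as thermodynamic solubility, with a stated time of 4 h, at pH 6.8 (a higher number here means a more soluble compound, a lower number a less soluble compound), compound 1 gives 0.9 ug/mL, compound 2 gives 16 ug/mL and compound 3 gives 17 ug/mL. Going by the values given here, the one step with a known size is an 18-fold higher number from compound 1 to compound 2 (1.25 log units; beyond the scatter). Compound 3 and compound 2 sit together within the scatter, so no order between them can be read; compound 1 lies far below both.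

Compound 4 `Cc1cccnc1Oc1ccc2nc(COc3cccc(C(=O)O)c3)n(C)c2c1` arises from compound 3 by the change (3-methylpyridin-2-yl in place of 5-chloropyridin-2-yl on an oxygen on an aromatic ring). Among the compounds with values here, no measured step of this kind exists among the three compounds: the step from compound 1 to compound 2 concerns an isomer swap on a dimethylphenyl group, not an exchange of chloro for methyl on a pyridinyl group, so it bears on compound 4 only as a sign that small changes on this aryl group can move the number strongly. Within the data shown here, with no closer precedent, a step within the scatter is expected, with wide uncertainty, namely a 1.2-fold higher number from compound 3 to compound 4 (0.07 log units; within the scatter). Compound 4 is therefore estimated at 20 ug/mL, in the range 6 ug/mL to 60 ug/mL.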

Compound 4, solubility: 37 ug/mL
Compound 4: the middle estimate sits 1.9-fold (0.27 log units) below what was measured; measured number inside the range.
By their numbers in this assay, from the lowest: compound 1; then compounds 2 and 3 (each within the scatter of the next); then compound 4.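

In this assay, going by these compounds alone, the exchange of 5-chloropyridin-2-yl for 3-methylpyridin-2-yl on an oxygen on an aromatic ring gives a 2.2-fold higher number from compound 3 to compound 4 (0.34 log units; beyond the scatter) and so provides the first measured step between two pyridinyl groups at this place, where the only earlier step, an 18-fold higher number from compound 1 to compound 2 (1.25 log units; beyond the scatter), joined two dimethylphenyl groups and is the larger of the two. The number moves beyond the scatter even though the groups that leave and enter have the same counted features: seven heavy atoms each, one six-membered aromatic ring with one hetero atom, the same count of hydrogen-bond donors and acceptors, and no net charge. Nothing measured on these compounds accounts for the step, so the reason for it remains unknown.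

The exchange alters both the substituent and where it stands on the pyridine, so compound 3 and compound 4 alone cannot separate these two changes, a question that 3-chloropyridin-2-yl or 5-methylpyridin-2-yl would address. Also open, on these data alone, is how the number would respond to a basic amine such as a morpholine on this aryl group, or to a primary amide in place of the carboxylic acid.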